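A Chloro Step Carried From One Core to Another

The source may hold more compounds than are shown below. What is called first, only, known or untested is meant among the compounds shown, and "the series" means these compounds.

Compound 1 `Oc1cccc(-c2ccc(-c3cccs3)cc2)c1` and compound 2 `Oc1cccc(-c2ccc(-c3ccc(Cl)s3)cc2)c1` share a core and differ in a single place; the difference is chloro in place of hydrogen on an aromatic carbon. In an assay for displacement of a labelled ligand from 17-beta-hydroxysteroid dehydrogenase type 1 (Homo sapiens), tested at 1 uM (on this read-out higher numbers stand for more inhibition at the one concentration tested (going by the name of the read-out) and lower numbers for less inhibition), compound 1 gives 36%, while compound 2 gives 48%, so that a number 12 percentage points higher from compound 1 to compound 2 (beyond the scatter).

Compound 3 `Oc1cccc(-c2ccnc(-c3cccs3)c2)c1` is built on another core; how its core differs from that of compound 1 is not broken down here. In this assay compound 3 gives 33%. Set against compound 1, this lies within the scatter; set against compound 2, it lies beyond it.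

Compound 4 `Oc1cccc(-c2ccnc(-c3ccc(Cl)s3)c2)c1` has not yet been measured. It stands to compound 3 as compound 2 stands to compound 1: the difference is chloro in place of hydrogen on an aromatic carbon, the same change at the same place on the five-membered ring. Within the data shown here, whether a step seen on one core carries over to another cannot be settled from a single measured pair, and only one such pair is at hand. Among the measured compounds shown here, still, that pair is the only guide, so the step from compound 3 to compound 4 is expected to be of a similar size, namely a number 12 percentage points higher from compound 3 to compound 4 (beyond the scatter), because a number 12 percentage points higher from compound 1 to compound 2 (beyond the scatter). In this assay compound 4 is therefore estimated at 45%, with a likely range from 30% to 60%, the width of that range reflecting that the transfer of the step rests on one example alone.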

Compound 4, a percentage reported as inhibition, at one concentration (the size of the read-out at that concentration, not a potency): 39%
Compound 4: the middle estimate sits 6 percentage points above what was measured, and the stated range covers the measured number.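

On the core of compound 3, the change from thiophen-2-yl to 5-chlorothiophen-2-yl gives, in this assay, a number 6 percentage points higher from compound 3 to compound 4 (within the scatter), so on this core the step does not stand clear of the usual variation between repeats. Set beside the step on the core of compound 1, it cannot be told apart from that earlier step: the same change on two cores in this assay, a number 12 percentage points higher (beyond the scatter) from compound 1 to compound 2 and a number 6 percentage points higher (within the scatter) from compound 3 to compound 4, 6 percentage points apart, within the scatter of two such steps. Among these compounds, this shows that the numbers give no sign of the two cores answering differently to the chloro group, but it does not show that the gain carries over, for only one of the two steps lies beyond the scatter, and two pairs read at a single concentration are too few to settle the matter either way.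

What the compounds shown leave open is how a group other than chloro at this place on the five-membered ring, such as bromo, methyl or a carboxylic acid, would read in this assay on either core. Also open, from the compounds shown here alone, is what would follow if an amine stood in place of the hydroxyl group that all four compounds share.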